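A phenyl swap from compound 3 to compound 4

This account rests on a few compounds, and the source may have more. Where it says the series, first, only, none or still open, it means among the compounds named here.

Of the compounds shown here, three sharing one core have been measured in a functional assay on A549 cells (Homo sapiens) for antiproliferative activity, read by MTT assay; a lower number here means a stronger inhibitor, a higher number a weaker inhibitor. Compound 1 `COc1cc2c(Oc3ccc(NC(=O)Nc4ccccc4)cc3)ccnc2cc1OCCCCCCC(=O)NO` gives 1650 nM, compound 2 `COc1cc2c(Oc3ccc(NC(=O)Nc4cccc(C)c4)cc3)ccnc2cc1OCCCCCCC(=O)NO` gives 2010 nM, and compound 3 `COc1cc2c(Oc3ccc(NC(=O)Nc4ccc(OC(F)(F)F)cc4)cc3)ccnc2cc1OCCCCCCC(=O)NO` gives 3130 nM. Compound 3 therefore cannot be told apart from the other two, as its number lies within the scatter of both: the data show a 1.9-fold higher number from compound 1 to compound 3 (0.28 log units; within the scatter) and a 1.6-fold higher number from compound 2 to compound 3 (0.19 log units; within the scatter).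

Compound 4 `COc1cc2c(Oc3ccc(NC(=O)Nc4ccc(Cl)c(C(F)(F)F)c4)cc3)ccnc2cc1OCCCCCCC(=O)NO` keeps the shared core and changes only the group on the amide-type nitrogen, with 4-chloro-3-(trifluoromethyl)phenyl in place of 4-(trifluoromethoxy)phenyl on an amide-type nitrogen. The measured steps that bear on this change are those that alter the same phenyl group. Besides the two already given, there is a 1.2-fold higher number from compound 1 to compound 2 (0.09 log units; within the scatter). Going by the values given here, none of the three leaves the scatter, although no measured compound carries the chloro or trifluoromethyl substituents, so the guidance is limited. No step beyond the scatter is therefore expected in this assay, and no firm direction can be given. The expected step is a 1.3-fold lower number from compound 3 to compound 4 (0.10 log units; within the scatter). Compound 4 is estimated at 2500 nM, with an expected range from 1100 nM to 5500 nM.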

Compound 4, half-maximal inhibitory concentration: 5020 nM
The estimate for compound 4 lay 2.0-fold (0.30 log units) below the measured number; measured number inside the range.
By their numbers in this assay, from the lowest: compounds 1, 2, 3 and 4 (each within the scatter of the next, the first and the last beyond it).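

In this assay, the group on the amide-type nitrogen now gives its first steps beyond the scatter: 4-chloro-3-(trifluoromethyl)phenyl in place of phenyl gives a 3.0-fold higher number from compound 1 to compound 4 (0.48 log units; beyond the scatter), and in place of 3-methylphenyl it gives a 2.5-fold higher number from compound 2 to compound 4 (0.40 log units; beyond the scatter), both modest, whereas every step among compounds 1, 2 and 3 stayed within the scatter. Against 4-(trifluoromethoxy)phenyl the same group gives a 1.6-fold higher number from compound 3 to compound 4 (0.21 log units; within the scatter), so compound 3 and compound 4 cannot be told apart, and this position is shown to be not wholly indifferent to what it carries, though only modestly so across these four compounds. No measurement is at hand that accounts for these steps.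

The compounds shown leave open how the chloro and the trifluoromethyl each contribute on their own to the higher number of compound 4. They also leave open how the position would respond to a carboxylic acid or an amine on the phenyl, and whether any group there can take the number clearly under that of compound 1 at 1650 nM.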